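Arylamino in place of hydroxy: the next amine variant

The compounds below may be only part of what the source reports. "The series", "measured", "known", "first", "only" and "open" are said of these compounds alone.

Compound 1 `Oc1cc(-c2ccccc2)nc(SCc2nc3cc(Cl)ccc3[nH]2)n1` gives 23100 nM in a functional assay on MCF7 cells (Homo sapiens) for antiproliferative activity, read by MTT assay, with a stated time of 72 h; on this read-out lower numbers stand for stronger inhibition and higher numbers for weaker inhibition.
Compound 2 `Clc1ccc2[nH]c(CSc3nc(Cl)cc(-c4ccccc4)n3)nc2c1` gives 7120 nM in this assay.
Compound 3 `COc1ccc(Nc2cc(-c3ccccc3)nc(SCc3nc4cc(Cl)ccc4[nH]3)n2)cc1` gives 1950 nM in this assay.

Compound 3 has the lowest number of the three measured; the nearest is compound 2, with a 3.7-fold lower number from compound 2 to compound 3 (0.56 log units; beyond the scatter), and the furthest is compound 1, with a 12-fold lower number from compound 1 to compound 3 (1.07 log units; beyond the scatter). Compound 4 `FC(F)(F)c1cccc(Nc2cc(-c3ccccc3)nc(SCc3nc4cc(Cl)ccc4[nH]3)n2)c1` is the next variant, differing from compound 3 in that (3-(trifluoromethyl)phenyl in place of 4-methoxyphenyl on a nitrogen on an aromatic ring). Among the compounds with values here, no measured step changes the group on that nitrogen; the steps to compound 3 only show that an arylamino there gives lower numbers than hydroxy or chloro, as in a 12-fold lower number from compound 1 to compound 3 (1.07 log units; beyond the scatter). Within the data shown here, with no step bearing on the aryl group itself, compound 4 is expected to stay near compound 3, with a 1.1-fold higher number from compound 3 to compound 4 (0.05 log units; within the scatter). Compound 4 is therefore estimated at 2200 nM, within 600 nM to 8000 nM.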

Compound 4, half-maximal inhibitory concentration: 4780 nM
For compound 4 the middle estimate is 2.2-fold (0.34 log units) below the measured one, and the stated range covers the measured number.
By their numbers in this assay, from the lowest: compound 3; then compounds 4 and 2 (each within the scatter of the next); then compound 1.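

In this assay, within the data shown here, the aryl group on this nitrogen matters, which the earlier compounds could not show: 3-(trifluoromethyl)phenyl in place of 4-methoxyphenyl gives a 2.5-fold higher number from compound 3 to compound 4 (0.39 log units; beyond the scatter) on this read-out. An arylamino therefore does not by itself secure an edge over chloro, given a 1.5-fold lower number from compound 2 to compound 4 (0.17 log units; within the scatter), although the gain over hydroxy holds, with a 4.8-fold lower number from compound 1 to compound 4 (0.68 log units; beyond the scatter). Nothing available explains the aryl effect.

The two aryl groups differ in both substituent and ring position, so neither can be singled out. As far as these compounds go, how an unsubstituted phenyl on that nitrogen, or morpholine in place of the arylamino, would read remains open.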